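Working notes: acetoxy in place of methyl

A few compounds are considered here, and "the series" means these few. Any claim that something is new, unique, unknown or untested is made for them only; others in the source may bear on it.

In a functional assay on HepG2 cells (Homo sapiens) for cytotoxicity, read by MTT assay, with a stated time of 72 h (a lower number here means a stronger inhibitor, a higher number a weaker inhibitor), compound 1 (`CC(=C\c1ccccc1)/C=C1\CCC=CC1=O`) gives 4600 nM and compound 3 (`COc1ccccc1/C=C/C=C1\CCC=CC1=O`) gives 5800 nM on closely related structures. Compound 2 (`Cc1ccc(/C=C/C=C2\CCC=CC2=O)cc1`) stands at 8600 nM and lies within the scatter of both others, so these numbers give the three compounds no order.

Going by the values given here, compound 4 (`CC(=O)Oc1ccc(/C=C/C=C2\CCC=CC2=O)cc1`) has no measurement yet. The change from compound 2 to compound 4 puts acetoxy in place of methyl on an aromatic carbon, para to a large group (acetoxy in place of methyl on an aromatic carbon) and leaves the rest of the structure as it is.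

Among the compounds with values here, no two measured compounds differ in one place only, so the series offers no measured step to carry over to this change. Within the data shown here, the only guide is the narrow spread of the measured numbers. With compound 2 at 8600 nM and the others within the scatter of it, a step beyond the scatter is not expected in this assay in either direction. The expected move is a 1.4-fold lower number from compound 2 to compound 4 (0.16 log units; within the scatter) and it would stay within the scatter. The estimated value for compound 4 is 6000 nM (expected range 2500 nM to 14000 nM).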

Compound 4, half-maximal inhibitory concentration: 4500 nM
Compound 4: the middle estimate sits 1.3-fold (0.12 log units) above what was measured, within the range that was stated.
By their numbers in this assay, from the lowest: compounds 4, 1, 3 and 2 (each within the scatter of the next).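

Acetoxy in place of methyl on an aromatic carbon, para to a large group, gives a 1.9-fold lower number from compound 2 to compound 4 (0.28 log units; within the scatter) in this assay and so does not separate the two compounds. Going by these compounds alone, this is the first change that can be read at a single place, and it shows that this position accepts a move from 1 heavy atom to 4 heavy atoms, with 2 hydrogen-bond acceptors entering where methyl has none, without a step beyond the scatter. The data hold no measurement that could explain this result, so the step stands as an observation only.

From the compounds shown here alone, whether the same position stays this flat with a group of another kind, such as a hydroxyl, an amine, a carboxylic acid or a longer alkyl chain, remains open, since one step within the scatter marks no limit on what the position accepts. Going by these compounds, it also remains open whether acetoxy in place of methyl would read the same on the core of compound 1 or on the core of compound 3, which carry their other groups elsewhere.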